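Methyl branching on the ester and amide side chains

A few compounds are considered here, and "the series" means these few. Any claim that something is new, unique, unknown or untested is made for them only; others in the source may bear on it.

Measured compounds:
Compound 1, `CCCOC(=O)C1=C(C)N(C)C(=O)NC1c1ccoc1`: 1%
Compound 2, `CC1=C(C(=O)OCC(C)C)C(c2ccoc2)NC(=O)N1C`: 4%
Compound 3, `CCNC(=O)C1=C(C)NC(=O)NC1c1cccs1`: 1%

In an assay on membranes from CHO cells for displacement of a labelled ligand from adenosine receptor A1 (Homo sapiens), read by scintillation counting, with a stated time of 60 min, tested at 1 uM (on this read-out lower numbers stand for less inhibition and higher numbers for more inhibition at the one concentration tested (going by the name of the read-out)), compound 1 gives 1% and compound 2 gives 4%. The two differ by methyl in place of hydrogen on a saturated chain carbon bound to two saturated chain carbons, and this step reads a number 3 percentage points higher from compound 1 to compound 2 (within the scatter). Compound 3 gives 1% in this assay, level with compound 1 at the digits recorded and together with it the lowest of the three numbers; the difference between the core of compound 3 and the core of compound 1 is not broken down here.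

Compound 4, `CC1=C(C(=O)NC(C)C)C(c2cccs2)NC(=O)N1`, has not yet been measured in this assay. It differs from compound 3 by methyl in place of hydrogen on a saturated chain carbon bound to an amide-type nitrogen and a saturated chain carbon. This is the same kind of change as that from compound 1 to compound 2, but not the same: in the first case the carbon that receives the methyl is bound to two saturated chain carbons, whereas in compound 4 it is bound to an amide-type nitrogen and a saturated chain carbon.

Since the earlier step, a number 3 percentage points higher from compound 1 to compound 2 (within the scatter), stayed within the scatter, the step from compound 3 to compound 4 is expected to be of about the same size, a number 2 percentage points higher from compound 3 to compound 4 (within the scatter). Compound 4 is therefore expected to give about 3% in this assay, most likely between -5% and 12%.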

Compound 4, a percentage reported as inhibition, at one concentration (the size of the read-out at that concentration, not a potency): 2%
Compound 4: middle estimate off by 1 percentage points, on the high side, and the stated range covers the measured number.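

In this assay, the new change, ethylcarbamoyl to isopropylcarbamoyl, gives a number 1 percentage points higher from compound 3 to compound 4 (within the scatter). Set beside the earlier methyl step on the ester side chain, it shows no difference that can be told from scatter, so in these two pairs the change carries from one core to the other without a detectable shift: the same change on two cores in this assay, a number 3 percentage points higher (within the scatter) from compound 1 to compound 2 and a number 1 percentage points higher (within the scatter) from compound 3 to compound 4, 2 percentage points apart, within the scatter of two such steps This agreement is a limited result: each step on its own lies within the scatter, so neither pair shows that the added methyl raises the read-out, and the match shows only that two small steps look alike, not that a real effect of the methyl has been transferred, nor how the change would behave on a compound with a much larger number at the one concentration tested.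

The compounds shown leave open whether a bulkier group on the same side chain, such as tert-butyl or a phenyl ring, would give a step beyond the scatter. They also leave open whether a carboxylic acid in place of the ester or the amide would move the read-out on either core.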